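The source may report more compounds than this note shows. Statements on the series, on what has been measured and on what is new or still open speak of the compounds shown alone.

Measured so far:
- compound 1 `NS(=O)(=O)Oc1ccc2c(c1)CN(C(=O)c1cccc(N3CCC(N4CCCCC4)CC3)c1)CC2`: 8%
- compound 2 `CCN(Cc1ccccc1)Cc1ccc(CN2CCc3ccc(OS(N)(=O)=O)cc3C2)cc1`: 17%
- compound 3 `CCN(Cc1ccccn1)c1ccc(C(=O)N2CCc3ccc(OS(N)(=O)=O)cc3C2)cc1`: 87.7%

All three compounds share the same core and were tested in an assay on HEK293 cells for inhibition of Steryl-sulfatase (Homo sapiens), tested at 1 uM; on this read-out lower numbers stand for a weaker effect and higher numbers for a stronger effect at the one concentration tested. Compound 3 stands highest of the three: in this assay compound 3 gives 87.7%, and both other numbers lie far lower, beyond the usual scatter of such measurements. Compound 2 gives 17% and compound 1 gives 8%.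

Compound 4 `CCN(Cc1ccc(F)cc1)c1ccc(C(=O)N2CCc3ccc(OS(N)(=O)=O)cc3C2)cc1` has not yet been measured. It differs from compound 3 in one place: 4-fluorophenyl in place of pyridin-2-yl on a saturated chain carbon bound to a nitrogen on an aromatic ring. For the measured compounds named here, no step between two measured compounds shows what such an exchange does, so only the single high number of compound 3 gives a starting point.

The step from compound 3 to compound 4 in this assay is expected to be a number 12.7 percentage points lower from compound 3 to compound 4 (beyond the scatter), that is, a small loss or none beyond the scatter. Compound 4 is therefore estimated to give 75% in this assay, within a range from 45% to 95%.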

Compound 4, a percentage reported as inhibition, at one concentration (the size of the read-out at that concentration, not a potency): 91.2%
Compound 4: middle estimate off by 16.2 percentage points, on the low side; low and high end bracket the measured number.
By their numbers in this assay, from the lowest: compounds 1 and 2 (each within the scatter of the next); then compounds 3 and 4 (each within the scatter of the next).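

In this assay, placing 4-fluorophenyl instead of pyridin-2-yl on the saturated chain carbon bound to a nitrogen on an aromatic ring gives a number 3.5 percentage points higher from compound 3 to compound 4 (within the scatter). This is the first view of a single change among these compounds, and it shows that the high read-out survives the loss of the ring nitrogen and the gain of a fluorine, so this position accepts both a carbon-only aromatic ring and one with a hetero atom. Nothing measured here explains this result, and a read-out at one concentration cannot separate the potencies of the two compounds.

From the compounds shown here alone, it remains open whether this position needs an aromatic ring at all, which a saturated cyclohexyl group could test. A plain phenyl group would show whether the fluorine matters, and a carboxylic acid on the ring would probe a more drastic change.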